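Moving a fluorine on the urea phenyl ring

The source may report more compounds than this note shows. Statements on the series, on what has been measured and on what is new or still open speak of the compounds shown alone.

Of the compounds shown here, three sharing one core have been measured in a functional assay on cells (Neutrophil, Homo sapiens) for inhibition, with a stated time of 10 min; on this read-out lower numbers stand for stronger inhibition and higher numbers for weaker inhibition. Compound 1, `CCOC(=O)c1cnn(CC(C)O)c1NC(=O)NCc1ccccc1`, gives 15 nM. Compound 2, `CCCC(O)Cn1ncc(C(=O)OCC)c1NC(=O)NC(C)C`, gives 20 nM. Compound 3, `CCOC(=O)c1cnn(CC(O)CC)c1NC(=O)Nc1ccccc1F`, gives 120 nM, which is the highest of the three numbers: the gap from compound 2 to compound 3 and the gap from compound 1 to compound 3 both lie beyond the usual scatter of this assay, so compound 3 is the weakest inhibitor of the three.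

Compound 4, `CCOC(=O)c1cnn(CC(O)CC)c1NC(=O)Nc1cccc(F)c1`, is built from the same atoms as compound 3, joined differently: 3-fluorophenyl in place of 2-fluorophenyl on an amide-type nitrogen. For the measured compounds named here, no measured pair in this set shows what such a move of the fluorine does, so there is no direct guide for the size or direction of the step. With nothing pointing one way, the step from compound 3 to compound 4 is expected to be small, a 1.2-fold lower number from compound 3 to compound 4 (0.08 log units; within the scatter), and may well fall within the scatter. Compound 4 is therefore estimated at 100 nM, with a range from 30 nM to 350 nM in this assay.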

Compound 4, half-maximal inhibitory concentration: 0.19 nM
Beside the measured number, compound 4's estimate is 530-fold (2.72 log units) above it; measured number below the stated range.
By their numbers in this assay, from the lowest: compound 4; then compounds 1 and 2 (each within the scatter of the next); then compound 3.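

In this assay, moving the fluorine on the amide-type nitrogen's phenyl ring gives a 630-fold lower number from compound 3 to compound 4 (2.80 log units; beyond the scatter) and adds or removes no atom, which shows that this position is highly sensitive to where the fluorine sits. The 2-fluorophenyl and 3-fluorophenyl groups have the same heavy atoms, the same aromatic ring, no hydrogen-bond donors or acceptors and no net charge, yet the assay separates them by a large margin, and none of those counts predicts the difference. Nothing given here accounts for the size of this step, and its cause remains unassigned.

As far as these compounds go, it remains open whether the fluorine is needed at all, and a plain phenyl group on the same nitrogen, with the rest of compound 4 unchanged, would help answer that. For the compounds shown here, it is also open whether a chlorine or a methoxy group in place of the fluorine would keep a number close to the one compound 4 gives, 0.19 nM in this assay, or would lose most of it, as the 2-fluorophenyl group of compound 3 does.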